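Notes on the aryl group carried by the ring nitrogen

This account rests on a few compounds, and the source may have more. Where it says the series, first, only, none or still open, it means among the compounds named here.

Compound 3 `CCCc1nc(-c2ccccc2)c(CNCCCN2CCN(c3ccccc3C)CC2)o1` sits second highest of the three numbers in hand: in an assay on HEK293 cells for inhibition of Voltage-dependent T-type calcium channel subunit alpha-1G (Homo sapiens), read by fluorescence, tested at 10 uM (on this read-out higher numbers stand for more inhibition at the one concentration tested (going by the name of the read-out) and lower numbers for less inhibition), compound 3 gives 54.5%. Compound 1 `CCCc1nc(-c2ccccc2)c(CNCCCN2CCN(c3cccc(Cl)c3)CC2)o1` stands furthest from it, as in this assay compound 1 gives 65.9%. Compound 2 `CCCc1nc(-c2ccccc2)c(CNCCCN2CCN(c3ccccc3C(F)(F)F)CC2)o1` is nearest, and in this assay compound 2 gives 45%. The steps behind these numbers are a number 11.4 percentage points lower from compound 1 to compound 3 (beyond the scatter), a number 20.9 percentage points lower from compound 1 to compound 2 (beyond the scatter), and a number 9.5 percentage points higher from compound 2 to compound 3 (within the scatter).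

Compound 4 `CCCc1nc(-c2ccccc2)c(CNCCCN2CCN(c3ccc(C)c(C)c3)CC2)o1` differs from compound 3 by 3,4-dimethylphenyl in place of 2-methylphenyl on an amine nitrogen in a ring. Among the compounds with values here, no measured step makes this exact exchange. Within the data shown here, the steps that bear on it are the two other exchanges of the aryl group on the ring nitrogen, a number 11.4 percentage points lower from compound 1 to compound 3 (beyond the scatter) and a number 20.9 percentage points lower from compound 1 to compound 2 (beyond the scatter), both modest and both beyond the scatter; the remaining step, a number 9.5 percentage points higher from compound 2 to compound 3 (within the scatter), lies within it. Each swap of the aryl group so far has shifted the read-out by a modest amount, so a shift of the same order is the reasonable expectation here, with the direction uncertain. A modest rise back toward the level of compound 1 is the estimate, a number 5.5 percentage points higher from compound 3 to compound 4 (within the scatter). Compound 4 is therefore expected to give 60% in this assay, with a range from 40% to 78%.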

Compound 4, a percentage reported as inhibition, at one concentration (the size of the read-out at that concentration, not a potency): 54.6%
For compound 4 the middle estimate is 5.4 percentage points above the measured one; measured number inside the range.
By their numbers in this assay, from the lowest: compounds 2, 3 and 4 (each within the scatter of the next); then compound 1.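

In this assay, 3,4-dimethylphenyl in place of 2-methylphenyl on the amine nitrogen in the ring gives a number 0.1 percentage points higher from compound 3 to compound 4 (within the scatter), so this exchange has no readable effect, and the 3,4-dimethylphenyl group joins the two aryl groups already level with each other. The step of a number 9.6 percentage points higher from compound 2 to compound 4 (within the scatter) is also within the scatter, placing compounds 2, 3 and 4 in one group despite their different aryl groups, while a number 11.3 percentage points lower from compound 1 to compound 4 (beyond the scatter) lies beyond it, so that compound 1, with 3-chlorophenyl, now stands apart from all three other compounds rather than from two. Nothing at hand gives a reason for this separation.

The series leaves open whether the higher number belongs to the chlorine itself or to its place on the ring, which 3-methylphenyl, 4-chlorophenyl or 2-chlorophenyl on the same nitrogen would help to separate. It also leaves open how an unsubstituted phenyl, a methoxyphenyl or a pyridyl group would read here, and every number remains a single-concentration inhibition rather than a potency.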